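The source may report more compounds than this note shows. Statements on the series, on what has been measured and on what is new or still open speak of the compounds shown alone.

Compound 1 `CC(C)(C)OC[C@@H](N)C(=O)N1CCN(CCCOc2ccc(C(=O)C3CC3)cc2)CC1` gives 45700 nM in an assay for binding affinity to histamine H2 receptor (Homo sapiens); on this read-out lower numbers stand for stronger inhibition and higher numbers for weaker inhibition. Its number is the lowest of the three measured here, though neither of the other two lies beyond the scatter: compound 3 `CCC[C@@H](N)C(=O)N1CCN(CCCOc2ccc(C(=O)C3CC3)cc2)CC1` gives 60300 nM, and compound 2 `CNCC(=O)N1CCN(CCCOc2ccc(C(=O)C3CC3)cc2)CC1` gives 79400 nM. Compound 4 `CN[C@@H](C(=O)N1CCN(CCCOc2ccc(C(=O)C3CC3)cc2)CC1)C(C)C` has not yet been measured. It differs from compound 1 in one place: 2-methyl-1-(methylamino)propyl in place of 1-amino-2-(tert-butoxy)ethyl on a carbonyl carbon. The same position on the carbonyl carbon has already been varied among the measured compounds, with a 1.7-fold higher number from compound 1 to compound 2 (0.24 log units; within the scatter) and a 1.3-fold lower number from compound 2 to compound 3 (0.12 log units; within the scatter), while a 1.3-fold higher number from compound 1 to compound 3 (0.12 log units; within the scatter). All three steps stay within the scatter, so the expected step of a 1.2-fold higher number from compound 1 to compound 4 (0.08 log units; within the scatter) is likewise none beyond the scatter. Compound 4 is therefore estimated at 55000 nM, within a range from 18000 nM to 170000 nM.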

Compound 4, inhibition constant: 49000 nM
Compound 4: middle estimate off by 1.1-fold (0.05 log units), on the high side, within the range that was stated.
By their numbers in this assay, from the lowest: compounds 1, 4, 3 and 2 (each within the scatter of the next).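

In this assay, putting 2-methyl-1-(methylamino)propyl on the carbonyl carbon gives a 1.1-fold higher number from compound 1 to compound 4 (0.03 log units; within the scatter), and setting it against 1-aminobutyl gives a 1.2-fold lower number from compound 3 to compound 4 (0.09 log units; within the scatter), so both comparisons stay within the scatter. Adding isopropyl in place of hydrogen on the saturated chain carbon bound to an amine nitrogen and a carbonyl carbon gives a 1.6-fold lower number from compound 2 to compound 4 (0.21 log units; within the scatter), so this substitution also stays within the scatter. Nothing available explains why these groups read alike. The compounds shown leave open whether any group on this carbonyl carbon, such as a carboxylic acid or a phenyl ring, would move the number beyond the scatter.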